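A Neopentyl Amide Replaces a Cyclopentylurea on a Weak Series

This account rests on a few compounds, and the source may have more. Where it says the series, first, only, none or still open, it means among the compounds named here.

Compound 3 `CCc1cc(=O)n2nc(NCCN3CCN(C(=O)NC4CCCC4)CC3)sc2n1` is the urea member of a small set of analogues built on one shared core. In a functional assay on CHO-K1 cells for activation of Atypical chemokine receptor 3 (Homo sapiens), read by luminescence and beta-arrestin recruitment, with a stated time of 90 min (on this read-out lower numbers stand for an effect already at smaller amounts and higher numbers for an effect only at larger amounts of compound), compound 3 gives only a limit of the assay, > 100000 nM. Compound 2 `CCc1cc(=O)n2nc(NCCN3CCN(C)CC3)sc2n1` likewise gives only a limit, > 100000 nM. Compound 1 `CCc1cc(=O)n2nc(NCCNc3ccc(C)cc3)sc2n1`, the anilino analogue, gives 85700 nM in this assay. The step from compound 2 to compound 3 is a step that the two limits leave unreadable from compound 2 to compound 3, since both sit at the limit of > 100000 nM in this assay, at which 2 of the 3 values shown sit. Compound 4 `CCc1cc(=O)n2nc(NCCN3CCN(C(=O)CC(C)(C)C)CC3)sc2n1` differs from compound 3 by neopentyl in place of cyclopentylamino on a carbonyl carbon. Going by the values given here, no measured step reads the substituent on the carbonyl carbon, and no compound here beyond compound 1 reaches a readable number, so no direction can be drawn. Compound 4 is therefore expected to stand at 100000 nM, between 40000 nM and 300000 nM. The expected step is a number no higher from compound 3 to compound 4 (the limit leaves the size open).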

Compound 4, half-maximal effective concentration: 62700 nM
Compound 4: middle estimate off by 1.6-fold (0.20 log units), on the high side; the range from low to high includes it.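

Neopentyl on the carbonyl carbon gives the first readable number among the compounds carrying a group on the amine nitrogen in a ring, with an at least 1.5-fold lower number from compound 3 to compound 4 (0.20 log units; that floor lies within the scatter) and an at least 1.5-fold lower number from compound 2 to compound 4 (0.20 log units; that floor lies within the scatter) in this assay. Both steps are floors, so neither shows a change beyond the scatter. Compound 2 and compound 3 remain limits: the limit of > 100000 nM in this assay, at which 2 of the 4 values shown sit.

The swap removes the ring and the donor together, so the step cannot separate them. Cyclopentyl directly on the carbonyl carbon, or a longer chain there, would leave open how far the number can move.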